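The compounds below may be only part of what the source reports. "The series", "measured", "known", "first", "only" and "open" are said of these compounds alone.

Measured in a functional assay on ECa-109 cells (Homo sapiens) for antiproliferative activity, read by MTT assay, with a stated time of 48 h; on this read-out higher numbers stand for weaker inhibition and lower numbers for stronger inhibition:
- compound 1 `Cn1cc(C2=C(c3nn(CCCn4ccnc4)c4ncccc34)C(=O)N(c3ccccc3)C2=O)c2ccccc21`: 1440 nM
- compound 2 `CN(C)CCCn1nc(C2=C(c3cn(C)c4ccccc34)C(=O)N(c3ccccc3)C2=O)c2cccnc21`: 5840 nM
- compound 3 `Cn1cc(C2=C(c3nn(CCCn4cccc4)c4ncccc34)C(=O)N(c3ccccc3)C2=O)c2ccccc21`: > 100000 nM (a limit)

Compound 3 stands only at a limit, > 100000 nM, and gives no number. Compound 4 `Cn1cc(C2=C(c3nn(CCCCn4ccnc4)c4ncccc34)C(=O)N(c3ccccc3)C2=O)c2ccccc21` differs from it by (1H-imidazol-1-yl)methyl in place of 1H-pyrrol-1-yl on a saturated chain carbon, three bonds along the chain from an aromatic nitrogen. This places (1H-imidazol-1-yl)methyl in place of 1H-pyrrol-1-yl on a saturated chain carbon, three bonds along the chain from an aromatic nitrogen, so 3-(1H-pyrrol-1-yl)propyl becomes 4-(1H-imidazol-1-yl)butyl.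

Within the data shown here, two measured steps bear on this, both large: an at least 69-fold higher number from compound 1 to compound 3 (1.84 log units; beyond the scatter) and an at least 17-fold higher number from compound 2 to compound 3 (1.23 log units; beyond the scatter). The former is the closer, being the same ring exchange in reverse. Among the measured compounds shown here, no measured step covers the longer chain. A large step towards a lower number is therefore expected in this assay, and its estimated size is an at least 40-fold lower number from compound 3 to compound 4 (1.60 log units; beyond the scatter). For compound 4 the estimate is 2500 nM, with an expected range of 500 nM to 15000 nM.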

Compound 4, half-maximal inhibitory concentration: 7540 nM
For compound 4 the middle estimate is 3.0-fold (0.48 log units) below the measured one; the range from low to high includes it.
By their numbers in this assay, from the lowest: compound 1; then compounds 2 and 4 (each within the scatter of the next). At a limit, above all of these: compound 3.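

In this assay, extending the chain to 4-(1H-imidazol-1-yl)butyl gives a 5.2-fold higher number from compound 1 to compound 4 (0.72 log units; beyond the scatter), so the added carbon costs activity without abolishing it. Exchanging the 3-(1H-pyrrol-1-yl)propyl chain for this one gives an at least 13-fold lower number from compound 3 to compound 4 (1.12 log units; beyond the scatter), but compound 3 is only a limit: the limit of > 100000 nM in this assay, at which 1 of the 4 values shown sits. Against the dimethylamino chain, the step is a 1.3-fold higher number from compound 2 to compound 4 (0.11 log units; within the scatter).

Still open, as far as these compounds go, is how a 4-(1H-pyrrol-1-yl)butyl chain would read, which would separate ring from chain length. Also open, from the compounds shown here alone, are a 5-(1H-imidazol-1-yl)pentyl chain and a terminal morpholine.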